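Halogenated bicyclic side chain on the hydroxy lactam series

This account rests on a few compounds, and the source may have more. Where it says the series, first, only, none or still open, it means among the compounds named here.

Measured in a functional assay on HeLa cells (Homo sapiens) for antiproliferative activity, read by MTT assay, with a stated time of 72 h (a higher number here means a weaker inhibitor, a lower number a stronger inhibitor), as follows:
- compound 1 `O=C1O/C(=C\Cn2cnc3c(F)nc(F)c(Cl)c32)C(OCc2ccccc2)=C1OCc1ccccc1` gives > 100000 nM as a limit of the assay
- compound 2 `O=C1NC(O)(CCn2cnc3cc[nH]c3c2=O)C(OCc2ccccc2)=C1OCc1ccccc1` gives 92000 nM as a single value
- compound 3 `O=C1NC(O)(CCn2cnc3ccn(CCC4(O)NC(=O)C(OCc5ccccc5)=C4OCc4ccccc4)c3c2=O)C(OCc2ccccc2)=C1OCc1ccccc1` gives 17000 nM; 18000 nM (2 entries) over repeated entries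

Within the data shown here, compound 2 holds the only single number, and it is higher than that of compound 3 at 17000 nM; 18000 nM (2 entries) in the same read-out. Compound 4 `O=C1NC(O)(CCn2cnc3cncc(Br)c32)C(OCc2ccccc2)=C1OCc1ccccc1` is still to be measured. Its change from compound 2 is a group of 10 heavy atoms (6 carbon, 3 nitrogen, 1 bromine; one five-membered aromatic ring with 2 hetero atoms, one six-membered aromatic ring with 1 hetero atom) in place of a group of 10 heavy atoms (6 carbon, 3 nitrogen, 1 oxygen; one five-membered aromatic ring with 1 hetero atom, one six-membered aromatic ring with 2 hetero atoms), on a saturated chain carbon, two bonds along the chain from a saturated ring carbon and the rest of the structure stays the same. Among the measured compounds shown here, no measured step covers this change. For the measured compounds named here, compound 3 at 17000 nM; 18000 nM (2 entries) shows only that lower numbers occur. A modest move towards a stronger inhibitor is expected, estimated as a 2.3-fold lower number from compound 2 to compound 4 (0.36 log units; beyond the scatter) with wide uncertainty. The estimate for compound 4 is 40000 nM with an expected range from 11000 nM to 120000 nM in this assay once measured.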

Compound 4, half-maximal inhibitory concentration: 77000 nM
Compound 4: middle estimate off by 1.9-fold (0.28 log units), on the low side; the measured number falls inside the stated range.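

In this assay, this exchange on a saturated chain carbon, two bonds along the chain from a saturated ring carbon, gives a 1.2-fold lower number from compound 2 to compound 4 (0.08 log units; within the scatter). The step therefore shows no separation at this place between the group carrying bromine, with 0 hydrogen-bond donors, and the group carrying oxygen, with 1 hydrogen-bond donor. Repeat entries elsewhere in the series agree closely: the several entries of compound 3 in this assay, 17000 nM; 18000 nM (2 entries)

The exchange alters the ring hetero atoms and the substituent together, so their separate contributions cannot be read. Going by these compounds, whether an amine in place of the bromine, or a longer chain carrying the same group, would move the number remains open.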